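Taking the Benzyl off Compound 3

A few compounds are considered here, and "the series" means these few. Any claim that something is new, unique, unknown or untested is made for them only; others in the source may bear on it.

In a functional assay on SGC-7901 cells (Homo sapiens) for antiproliferative activity, read by MTT assay, with a stated time of 72 h (a lower number here means a stronger inhibitor, a higher number a weaker inhibitor), compound 1 (`COc1ccc(-c2sc(C(=O)O)cc2-c2cc(OC)c(OC)c(OC)c2)cc1`) gives 7800 nM and compound 2 (`COc1ccc(-c2sc(C(=O)O)cc2-c2cc(OC)c(OC)c(OC)c2)cc1[N+](=O)[O-]`), which adds a nitro group, gives 23300 nM as a measured number. Compound 3 (`COc1ccc(-c2sc(C(=O)O)cc2-c2cc(OC)c(OC)c(OC)c2)cc1OCc1ccccc1`), which carries benzyloxy in place of that nitro, reads > 100000 nM as a limit of the assay and not a number. Compound 3 therefore stands at the limit of > 100000 nM in this assay, at which 1 of the 3 values shown sits, with no exact value.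

Compound 4 (`COc1ccc(-c2sc(C(=O)O)cc2-c2cc(OC)c(OC)c(OC)c2)cc1O`) differs from compound 3 by hydrogen in place of benzyl on an oxygen on an aromatic ring which turns benzyloxy to hydroxy. Going by the values given here, three measured steps bear on this change. Benzyloxy in place of hydrogen gave an at least 12-fold higher number from compound 1 to compound 3 (1.10 log units; beyond the scatter) and nitro in place of hydrogen gave a 3.0-fold higher number from compound 1 to compound 2 (0.48 log units; beyond the scatter) while benzyloxy in place of nitro gave an at least 4.2-fold higher number from compound 2 to compound 3 (0.63 log units; beyond the scatter) as well. Among the compounds with values here, the benzyl is the part that compound 4 lacks, so most of the large step of an at least 12-fold higher number from compound 1 to compound 3 (1.10 log units; beyond the scatter) is expected to be reversed in this assay even though no measured compound carries hydroxy. The expected change is an at least 9.0-fold lower number from compound 3 to compound 4 (0.95 log units; beyond the scatter) toward a lower number, which would be a large step. Compound 4 is estimated at 11000 nM within an expected range from 3500 nM to 35000 nM on this reasoning.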

Compound 4, half-maximal inhibitory concentration: 6100 nM
The estimate for compound 4 lay 1.8-fold (0.26 log units) above the measured number, within the range that was stated.
By their numbers in this assay, from the lowest: compounds 4 and 1 (each within the scatter of the next); then compound 2. At a limit, above all of these: compound 3.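

Compound 3 reads as a limit of the assay and not a number, so any step from it has only one firm end: the limit of > 100000 nM in this assay, at which 1 of the 4 values shown sits.

In this assay, hydrogen in place of benzyl on an oxygen on an aromatic ring gives an at least 16-fold lower number from compound 3 to compound 4 (1.21 log units; beyond the scatter), which shows that the oxygen can stay at this place and that the loss seen with benzyloxy goes with the benzyl. Hydroxy cannot be told apart from plain hydrogen on this carbon, with a 1.3-fold lower number from compound 1 to compound 4 (0.11 log units; within the scatter), while hydroxy in place of nitro gives a 3.8-fold lower number from compound 2 to compound 4 (0.58 log units; beyond the scatter), so the hydroxy compound sits with the unsubstituted compound and not with the nitro compound.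

On these data alone, whether an amine or an ethoxy group at this place would read with hydroxy and hydrogen, or with nitro and benzyloxy, stays open. It is also unsettled which part of the benzyl goes with the loss, the aromatic ring or simply a longer chain on the oxygen, such as a propyl chain.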